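This account rests on a few compounds, and the source may have more. Where it says the series, first, only, none or still open, it means among the compounds named here.

Of the compounds shown here, two sharing one core have been measured in a functional assay on RAW264.7 cells (Mus musculus) for inhibition, read by immunoassay, with a stated time of 12 h, tested at 30 uM; on this read-out lower numbers stand for less inhibition and higher numbers for more inhibition at the one concentration tested (going by the name of the read-out). Compound 1 `CCCOc1ccccc1C1CC(=O)c2ccccc2O1` gives 45.7% in this assay. Going by the values given here, compound 2 `O=C1CC(c2ccccc2OCc2ccccc2)Oc2ccccc21` gives 93.2% in this assay, the higher of the two numbers, and the single step between them, a number 47.5 percentage points higher from compound 1 to compound 2 (beyond the scatter), is large and beyond the scatter. Compound 3 `COc1ccccc1C1CC(=O)c2ccccc2O1` has not yet been measured in this assay. It differs from compound 2 by hydrogen in place of phenyl on a saturated chain carbon bound to an oxygen on an aromatic ring. That earlier step bears directly on this change: there a phenyl entered on the same saturated chain carbon bound to an oxygen on an aromatic ring and the number rose sharply, whereas here the phenyl leaves and only hydrogen remains. The expected outcome is therefore a downward step beyond the scatter, a number 53.2 percentage points lower from compound 2 to compound 3 (beyond the scatter), in this assay. Compound 3 is expected to give about 40%, within a range from 15% to 70%. This expectation rests on compound 1 and compound 2 alone.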

Compound 3, a percentage reported as inhibition, at one concentration (the size of the read-out at that concentration, not a potency): 37.3%
The estimate for compound 3 lay 2.7 percentage points above the measured number; the measured number falls inside the stated range.
By their numbers in this assay, from the lowest: compounds 3 and 1 (each within the scatter of the next); then compound 2.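

In this assay, hydrogen in place of phenyl on the saturated chain carbon bound to an oxygen on an aromatic ring gives a number 55.9 percentage points lower from compound 2 to compound 3 (beyond the scatter), so the high number of compound 2 is lost when benzyloxy gives way to methoxy. Hydrogen in place of ethyl at the same place gives a number 8.4 percentage points lower from compound 1 to compound 3 (within the scatter), so compound 1 and compound 3 cannot be told apart, and among these three compounds only the phenyl sets one apart from the others. Nothing available explains this difference. The compounds shown leave open whether another ring at this place, such as cyclohexyl or pyridyl, would keep the high number of compound 2, or whether it takes the phenyl itself. They also leave open what a longer chain, an amine or a carboxylic acid would do there.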